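The source may report more compounds than this note shows. Statements on the series, on what has been measured and on what is new or still open speak of the compounds shown alone.

Three compounds built on the shared core of compound 3 `Cc1nn(C)c(-n2cccn2)c1/C=N/OCc1ccc(C(=O)OC(C)(C)C)cc1` have been tested in a functional assay on SK-MEL-2 cells (Homo sapiens) for cytotoxicity; on this read-out higher numbers stand for weaker inhibition and lower numbers for stronger inhibition. Compound 3 gives 28.8 ug/mL there. Compound 1 `Cc1nn(C)c(-n2cccc2)c1/C=N/OCc1ccc(C(=O)OC(C)(C)C)cc1` gives 24.9 ug/mL and compound 2 `Cc1nn(C)c(Oc2ccc(Cl)cc2)c1/C=N/OCc1ccc(C(=O)OC(C)(C)C)cc1` gives 18.8 ug/mL, so all three numbers lie within the scatter of one another: a 1.2-fold higher number from compound 1 to compound 3 (0.06 log units; within the scatter) and a 1.5-fold higher number from compound 2 to compound 3 (0.19 log units; within the scatter), while a 1.3-fold lower number from compound 1 to compound 2 (0.12 log units; within the scatter).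

Compound 4 `Cc1nn(C)c(Sc2ccccc2)c1/C=N/OCc1ccc(C(=O)OC(C)(C)C)cc1` differs from compound 3 by phenylsulfanyl in place of 1H-pyrazol-1-yl on an aromatic carbon. The two steps that bear on this change are those in which the 1H-pyrazol-1-yl group entered in place of another group on the same aromatic carbon: a 1.2-fold higher number from compound 1 to compound 3 (0.06 log units; within the scatter) and a 1.5-fold higher number from compound 2 to compound 3 (0.19 log units; within the scatter). Going by the values given here, both stayed within the scatter, and the one six-membered carbon ring group measured so far, in compound 2, gave a number within the scatter of the others. Compound 4 is therefore expected to show no step beyond the scatter in this assay, with a 1.3-fold lower number from compound 3 to compound 4 (0.12 log units; within the scatter) as the estimated change. The estimate for compound 4 is 22 ug/mL, with a range from 11 ug/mL to 44 ug/mL.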

Compound 4, half-maximal inhibitory concentration: 4.91 ug/mL
Estimate against measurement, compound 4: 4.5-fold (0.65 log units) above, and the stated range ends above it.
By their numbers in this assay, from the lowest: compound 4; then compounds 2, 1 and 3 (each within the scatter of the next).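

Going by these compounds alone, at this aromatic carbon, next to the ring nitrogen, phenylsulfanyl is the first group to move the number beyond the scatter in this assay, with the same direction against all three earlier groups (a 5.9-fold lower number from compound 3 to compound 4 (0.77 log units; beyond the scatter); a 5.1-fold lower number from compound 1 to compound 4 (0.71 log units; beyond the scatter); a 3.8-fold lower number from compound 2 to compound 4 (0.58 log units; beyond the scatter)). The step from 4-chlorophenoxy matters most, since that group also carries a six-membered aromatic ring of carbon only, so such a ring at this position is not enough on its own to separate a compound from the others. No measurement bears on why phenylsulfanyl stands apart.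

Phenylsulfanyl and 4-chlorophenoxy differ both in the linking atom and in the chlorine, so the compounds shown cannot tell these two apart. They also leave open how an unsubstituted phenoxy group, or a phenyl ring joined through an amine, would behave at this carbon.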